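Hydroxy in place of trifluoromethoxy on the terminal ring

The compounds below may be only part of what the source reports. "The series", "measured", "known", "first", "only" and "open" are said of these compounds alone.

In a functional assay on KB cells (Homo sapiens) for inhibition, read by sulforhodamine B assay (a lower number here means a stronger inhibitor of growth, a higher number a weaker inhibitor of growth), compound 2 (`Oc1cccc2[nH]c(-c3ccc(-c4ccc(-c5ccc(OC(F)(F)F)cc5)cc4)cc3)nc12`) gives 3310 nM as the lower of two numbers, while compound 1 (`Oc1cccc2[nH]c(-c3ccc(-c4ccc(-c5ccc(F)cc5)cc4)cc3)nc12`) gives 6920 nM as the higher. Compound 3 (`Oc1ccc(-c2ccc(-c3ccc(-c4nc5c(O)cccc5[nH]4)cc3)cc2)cc1`) turns trifluoromethoxy to hydroxy (hydrogen in place of trifluoromethyl on an oxygen on an aromatic ring), with hydrogen in place of trifluoromethyl on an oxygen on an aromatic ring. Going by the values given here, the only measured step, a 2.1-fold lower number from compound 1 to compound 2 (0.32 log units; beyond the scatter) and modest, comes from changing the same substituent, and no hydroxy compound has been measured yet. A modest rise in this assay is therefore expected, estimated as a 1.7-fold higher number from compound 2 to compound 3 (0.22 log units; within the scatter) with uncertain size. For compound 3 the expected value is 5500 nM with an estimated range from 1800 nM to 15000 nM for this measurement.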

Compound 3, concentration for 50% growth inhibition: 3190 nM
Compound 3: the middle estimate sits 1.7-fold (0.24 log units) above what was measured; measured number inside the range.
By their numbers in this assay, from the lowest: compounds 3 and 2 (each within the scatter of the next); then compound 1.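

In this assay, hydrogen in place of trifluoromethyl on an oxygen on an aromatic ring gives a 1.0-fold lower number from compound 2 to compound 3 (0.02 log units; within the scatter) and so separates neither compound from the other. Hydroxy in place of fluoro gives a 2.2-fold lower number from compound 1 to compound 3 (0.34 log units; beyond the scatter) and thus matches what trifluoromethoxy did, leaving fluoro as the only one of these three groups set apart from the others. No evidence on any property of these compounds bears on this result.

Going by these compounds, whether the level shared by hydroxy and trifluoromethoxy extends to other groups stays open. A methoxy, an amine or a carboxylic acid at this position would test that.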